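Biaryl sulfonamide piperidines: removing the methoxy

The source may report more compounds than this note shows. Statements on the series, on what has been measured and on what is new or still open speak of the compounds shown alone.

Measured so far:
compound 1 `COc1ccccc1-c1cccc(S(=O)(=O)N2CCC(N3CCC(C)CC3)CC2)c1` — > 5000 nM
compound 2 `COc1ccc(-c2ccccc2S(=O)(=O)N2CCC(N3CCC(C)CC3)CC2)cc1` — > 5000 nM

In an ADME assay on HCT-116 cells (Homo sapiens) for cytotoxicity, read by CellTiter-Glo, with a stated time of 72 h (a higher number here means a weaker inhibitor, a lower number a stronger inhibitor), compound 1 gives > 5000 nM, a limit of the assay rather than a number. Compound 2 likewise gives > 5000 nM, also a limit. Compound 1 therefore stands at the limit of > 5000 nM in this assay, at which 2 of the 2 values shown sit. Compound 3 `CC1CCN(C2CCN(S(=O)(=O)c3cccc(-c4ccccc4)c3)CC2)CC1` differs from compound 1 by hydrogen in place of methoxy on an aromatic carbon. Among the compounds with values here, no measured step exists between these compounds, so in this assay no shift beyond the scatter is expected, in either direction. Compound 3 is expected at 7000 nM, within 2500 nM to 20000 nM. The estimate implies a step that the limit leaves unreadable from compound 1 to compound 3, expected to stay within the scatter, most likely reported again as a limit.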

Compound 3, half-maximal inhibitory concentration: > 5000 nM
Compound 3: only a limit was reported (the forecaster's own chance of this, stated with the estimate: 80%); the middle value does not contradict the limit.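

Compound 1 and compound 3 both stand only as limits in this assay, so hydrogen in place of methoxy gives no readable step: the limit of > 5000 nM in this assay, at which 3 of the 3 values shown sit.

The compounds shown leave open whether any change to the shared core would give a number rather than a limit.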